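Methylsulfonyl in place of arylsulfonyl: notes on compound 3

A few compounds are considered here, and "the series" means these few. Any claim that something is new, unique, unknown or untested is made for them only; others in the source may bear on it.

Measured so far in a functional assay on MCF7 cells (Homo sapiens) for cytotoxicity, read by MTT assay, with a stated time of 48 h; on this read-out higher numbers stand for weaker inhibition and lower numbers for stronger inhibition:
compound 1 `CCN(CC)c1ccc2cc(C(=O)c3ccc(N4CCN(S(=O)(=O)c5ccc(Br)cc5)CC4)cc3)oc2c1` — 26100 nM
compound 2 `CCN(CC)c1ccc2cc(C(=O)c3ccc(N4CCN(S(=O)(=O)c5ccc(Br)c(F)c5)CC4)cc3)oc2c1` — 2270 nM

Among the compounds with values here, compound 2 gives the lowest number of the two; the single measured step, an 11-fold lower number from compound 1 to compound 2 (1.06 log units; beyond the scatter), separates it from compound 1 and lies beyond the scatter.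

Compound 3 `CCN(CC)c1ccc2cc(C(=O)c3ccc(N4CCN(S(C)(=O)=O)CC4)cc3)oc2c1` differs from compound 2 by methyl in place of 4-bromo-3-fluorophenyl on a sulfonyl sulfur. Within the data shown here, no measured step removes the whole aryl group from the sulfonyl sulfur; the only step on hand, an 11-fold lower number from compound 1 to compound 2 (1.06 log units; beyond the scatter), shows that the read-out is sensitive to what is carried on that ring, since fluoro alone moved the number beyond the scatter. Taking away the ring entirely is a larger change than that, and with no direct precedent the expectation is a weaker result, so compound 3 is estimated at 20000 nM (range 4000 nM to 80000 nM), an expected step of an 8.8-fold higher number from compound 2 to compound 3 (0.95 log units; beyond the scatter) in this assay.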

Compound 3, half-maximal inhibitory concentration: > 40000 nM
Compound 3 ended at the assay's limit; the forecaster's own chance of this, stated with the estimate: 20%; middle value at least 2.0-fold (0.30 log units) away from the limit.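

In this assay compound 3 stands at > 40000 nM, which is a limit of the assay and not a number, so this position can be read here only through a floor: the limit of > 40000 nM in this assay, at which 1 of the 3 values shown sits.

Methyl in place of 4-bromo-3-fluorophenyl on a sulfonyl sulfur gives an at least 17-fold higher number from compound 2 to compound 3 (1.24 log units; beyond the scatter), so the low number of compound 2 does not survive the loss of that ring. Methyl in place of 4-bromophenyl gives an at least 1.5-fold higher number from compound 1 to compound 3 (0.18 log units; that floor lies within the scatter); with that floor within the scatter, compound 1 and compound 3 cannot be ordered, and only the fluoro-bearing ring of compound 2 stands clearly apart from methyl.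

Open, as far as these compounds go, is how unsubstituted phenyl, benzyl or a longer chain such as butyl would read on the sulfonyl sulfur. Also open, from the compounds shown here alone, is whether the ring itself or its bromo and fluoro substituents set the number of compound 2.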